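The source may report more compounds than this note shows. Statements on the series, on what has been measured and on what is new or still open speak of the compounds shown alone.

Compound 1 `COc1ccc(NC(=O)Nn2c(-c3ccccc3)nc3ccccc3c2=O)cc1` — 52%
Compound 2 `O=C(Nc1ccc(I)cc1)Nn1c(-c2ccccc2)nc2ccccc2c1=O` — 60%
Compound 3 `O=C(Nc1ccccc1)Nn1c(-c2ccccc2)nc2ccccc2c1=O` — 56%

In a functional assay on the whole organism (strain albino) with Mus musculus as the target, at a dose of 100 mg/kg by the intraperitoneal route (on this read-out higher numbers stand for more inhibition at the one dose given (going by the name of the read-out) and lower numbers for less inhibition), compound 3 gives 56%, which sits between the other two numbers: a number 4 percentage points higher from compound 1 to compound 3 (within the scatter) and a number 4 percentage points lower from compound 2 to compound 3 (within the scatter), so all three lie within the scatter of one another. Compound 4 is `Cc1ccc(NC(=O)Nn2c(-c3ccccc3)nc3ccccc3c2=O)cc1`; the change from compound 3 is methyl in place of hydrogen on an aromatic carbon. Going by the values given here, the steps that bear on this position are those in which methoxy and iodo were each replaced by hydrogen on the same aromatic carbon, and neither moved this assay beyond the scatter. Putting a methyl there is therefore expected to leave the read-out essentially where it is, with no change at the digits printed from compound 3 to compound 4 (within the scatter). Compound 4 is estimated at 56%, in the range 44% to 68%.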

Compound 4, a percentage reported as inhibition, in the whole organism at one dose (the size of the read-out at that dose, not a potency): 54%
For compound 4 the middle estimate is 2 percentage points above the measured one; the range from low to high includes it.
By their numbers in this assay, from the lowest: compounds 1, 4, 3 and 2 (each within the scatter of the next).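

In this assay methyl now joins hydrogen, methoxy and iodo on this aromatic carbon, and it stays within the scatter of all three, with a number 2 percentage points lower from compound 3 to compound 4 (within the scatter) and a number 6 percentage points lower from compound 2 to compound 4 (within the scatter) and a number 2 percentage points higher from compound 1 to compound 4 (within the scatter) as the steps. A one-carbon group at this place, para to a large group, thus gives a number that cannot be told apart from the others. Nothing measured here offers an account of this flat result.

Going by these compounds, whether an amine, a carboxylic acid or a longer chain at this place would also stay within the scatter remains open. So does whether a change elsewhere on the shared core would move the number beyond it.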